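A few compounds are considered here, and "the series" means these few. Any claim that something is new, unique, unknown or untested is made for them only; others in the source may bear on it.

Measured compounds:
compound 1 `Nc1cc(N)c2nc(-c3ccccc3)c(NCc3ccc(Cl)c(Cl)c3)nc2c1` — 83200 nM
compound 2 `Nc1cc(N)c2nc(-c3ccccc3)c(Sc3ccc(Cl)c(Cl)c3)nc2c1` — < 100000 nM
compound 3 `CCOC(=O)[C@H](CCC(=O)O)NC(=O)c1ccc(CNc2nc3cc(N)cc(N)c3nc2-c2ccccc2)cc1` — < 100000 nM

Going by the values given here, in a functional assay on SF-539 cells (Homo sapiens) for inhibition, read by sulforhodamine B assay, with a stated time of 48 h (on this read-out higher numbers stand for lower toxicity in this test and lower numbers for higher toxicity in this test), compound 1 gives 83200 nM, the only plain number in this set. For compound 2 the result is reported as a limit of the test, < 100000 nM. For compound 3 the result is likewise a limit, < 100000 nM. Thus compound 1 stands alone as a measured number, and the only support around it is the limit of < 100000 nM in this assay, at which 2 of the 3 values shown sit.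

Compound 4 `Nc1cc(N)c2nc(-c3ccccc3)c(NCc3ccc(F)cc3)nc2c1` is not yet measured. It differs from compound 1 in one place: 4-fluorophenyl in place of 3,4-dichlorophenyl on a saturated chain carbon bound to a nitrogen on an aromatic ring. Among the compounds with values here, no measured pair in this set shares that change, so nothing here tells how the 3,4-dichlorobenzyl to 4-fluorobenzyl change acts in this assay. Within the data shown here, with only one number and two limits to go by, the step from compound 1 to compound 4 is expected to stay within the usual scatter, with no direction favoured, estimated as a 1.0-fold higher number from compound 1 to compound 4 (0.01 log units; within the scatter). Compound 4 is therefore expected to give about 85000 nM, within 40000 nM to 100000 nM, with a fair chance that only a limit is reported.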

Compound 4, concentration lethal to 50% of the cells: 6920 nM
Beside the measured number, compound 4's estimate is 12-fold (1.09 log units) above it, outside the stated range (below it).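

In this assay, going from 3,4-dichlorobenzyl to 4-fluorobenzyl gives a 12-fold lower number from compound 1 to compound 4 (1.08 log units; beyond the scatter), so toxicity in this test clearly responds to the group at this place. The earlier compounds shown here could not show this, as they offered a single plain number and otherwise only a limit of the test: the limit of < 100000 nM in this assay, at which 2 of the 4 values shown sit. The step from compound 2 to compound 4 cannot be read.

A single step cannot separate the loss of the two chlorine atoms from the arrival of the fluorine, and a plain benzyl or a 4-chlorobenzyl group would bear on that question. On these data alone, it also remains open whether 4-fluorobenzyl would act the same way on a sulfur link or with a longer chain.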